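The source may report more compounds than this note shows. Statements on the series, on what has been measured and on what is new or still open speak of the compounds shown alone.

Measured so far:
compound 1, `c1ccc(CSc2nnc(-c3ccc4c(c3)OCCO4)n2-c2ccccc2)cc1`: 7930 nM
compound 2, `Fc1ccc(CSc2nnc(-c3ccc4c(c3)OCCO4)n2-c2ccccc2)cc1`: 20800 nM
compound 3, `Fc1cccc(F)c1CSc1nnc(-c2ccc3c(c2)OCCO3)n1-c1ccccc1`: 9010 nM

All three values come from a functional assay on SW 1116 cells (Homo sapiens) for antiproliferative activity, read by MTT assay, with a stated time of 24 h; a higher number here means a weaker inhibitor, a lower number a stronger inhibitor. Compound 1 holds the lowest of the three numbers; compound 3 sits within the scatter of it, whereas compound 2 gives a clearly higher number, a 2.6-fold higher number from compound 1 to compound 2 (0.42 log units; beyond the scatter). Compound 4, `Brc1cccc(CSc2nnc(-c3ccc4c(c3)OCCO4)n2-c2ccccc2)c1`, has not yet been measured. It differs from compound 1 by a single change: bromo in place of hydrogen on an aromatic carbon. The step that bears most on this is the one where another halogen entered, a 2.6-fold higher number from compound 1 to compound 2 (0.42 log units; beyond the scatter), a modest weakening. The step of a 2.3-fold lower number from compound 2 to compound 3 (0.36 log units; beyond the scatter) shows that a different halogen pattern can bring the number back down. A modest rise is therefore expected, a 1.5-fold higher number from compound 1 to compound 4 (0.18 log units; within the scatter). For compound 4 the estimate in this assay is 12000 nM, with an expected range from 5000 nM to 30000 nM.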

Compound 4, half-maximal inhibitory concentration: 26200 nM
Estimate against measurement, compound 4: 2.2-fold (0.34 log units) below, and the stated range covers the measured number.
By their numbers in this assay, from the lowest: compounds 1 and 3 (each within the scatter of the next); then compounds 2 and 4 (each within the scatter of the next).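

In this assay the 3-bromobenzyl group also goes with a weaker result than plain benzyl (a 3.3-fold higher number from compound 1 to compound 4 (0.52 log units; beyond the scatter)), so this second halogen on the benzyl ring moves the number the same way as the fluoro did. The 3-bromobenzyl and 4-fluorobenzyl compounds cannot be told apart (a 1.3-fold higher number from compound 2 to compound 4 (0.10 log units; within the scatter)), whereas the 2,6-difluorobenzyl compound keeps the lower number (a 2.9-fold higher number from compound 3 to compound 4 (0.46 log units; beyond the scatter)), so having a halogen on the ring does not by itself set the result. Nothing measured here explains these shifts. Still open, on these data alone, is how an amine or a carboxylic acid on this ring would behave, and whether a 4-bromobenzyl group would match the 3-bromobenzyl one.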